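This account rests on a few compounds, and the source may have more. Where it says the series, first, only, none or still open, it means among the compounds named here.

Measured in a functional assay on Raji cells (Homo sapiens) for antiproliferative activity, read by CCK-8 assay, with a stated time of 72 h; on this read-out higher numbers stand for weaker inhibition and lower numbers for stronger inhibition:
- Compound 1 `C=CC(=O)Nc1cccc(Nc2nc(Nc3ccc(OCC(=O)N4CCCC4C(=O)OC)cc3)ncc2Cl)c1` gives 6700 nM
- Compound 2 `C=CC(=O)Nc1cccc(Nc2nc(Nc3ccc(Cn4cc(C)nc4CC)cc3)ncc2Cl)c1` gives < 10900 nM

For compound 2 the figure < 10900 nM is a limit of the assay and not a number. Compound 3 `C=CC(=O)Nc1cccc(Nc2nc(Nc3ccc(Cn4cc(C)nc4CC)cc3)ncc2F)c1` differs from it in one place: fluoro in place of chloro on an aromatic carbon. Among the compounds with values here, no measured pair here shows this swap, so no step beyond the usual scatter is expected in this assay, and no direction can be favoured. Within the data shown here, the estimate leans on compound 1 at 6700 nM, the only exact number available. The estimated change is a step that the limit leaves unreadable from compound 2 to compound 3. For compound 3 the expected value is 7000 nM, with an estimated range of 2000 nM to 20000 nM.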

Compound 3, half-maximal inhibitory concentration: < 10900 nM
Compound 3 ended at the assay's limit; the forecaster's own chance of this, stated with the estimate: 20%; the middle value is on the limit's open side.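

Compound 2 and compound 3 both end at a limit of the assay and not at a number, so no step can be read for fluoro in place of chloro: the limit of < 10900 nM in this assay, at which 2 of the 3 values shown sit.

The compounds shown leave open whether this swap changes the read-out at all.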